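Removing the Ring Hydroxy from a Propargylamine Inhibitor

The source may report more compounds than this note shows. Statements on the series, on what has been measured and on what is new or still open speak of the compounds shown alone.

Measured so far:
- compound 1, `C#CCN(Cc1ccccc1)Cc1cc2ccccc2n1C`: 10000 nM
- compound 2, `C#CCN(C)Cc1cc2cc(O)ccc2n1C`: 3.98 nM

Of the compounds shown here, two have been tested in an assay on isolated protein for inhibition of Amine oxidase [flavin-containing] A (Rattus norvegicus); a lower number here means a stronger inhibitor, a higher number a weaker inhibitor. Compound 1, `C#CCN(Cc1ccccc1)Cc1cc2ccccc2n1C`, gives 10000 nM in this assay. Compound 2, `C#CCN(C)Cc1cc2cc(O)ccc2n1C`, gives 3.98 nM in this assay, the lower of the two numbers and therefore the stronger inhibitor; the gap between them lies well beyond the usual scatter. The two differ in more than one place, so no single change can be credited for that gap.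

Compound 3, `C#CCN(C)Cc1cc2ccccc2n1C`, has not yet been measured. It differs from compound 2 in one place: hydrogen in place of hydroxy on an aromatic carbon. Going by the values given here, no measured pair shows this change alone, so its effect can only be guessed. The expectation is that compound 3 will be a weaker inhibitor than compound 2, with a step of a 13-fold higher number from compound 2 to compound 3 (1.10 log units; beyond the scatter), well beyond the scatter but far short of the gap to compound 1. Compound 3 is therefore estimated at 50 nM in this assay, in a range from 10 nM to 300 nM.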

Compound 3, inhibition constant: 0.302 nM
Estimate against measurement, compound 3: 170-fold (2.22 log units) above; the measured number lies below the stated range.
By their numbers in this assay, from the lowest: compound 3; then compound 2; then compound 1.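

In this assay, the hydroxy on this aromatic carbon proves unnecessary for strong inhibition: hydrogen in its place gives a 13-fold lower number from compound 2 to compound 3 (1.12 log units; beyond the scatter), so this position does not depend on a hydrogen-bond donor or acceptor being present in this pair. Compound 3 also isolates a second change, and hydrogen in place of phenyl on a saturated chain carbon bound to an amine nitrogen gives a 33000-fold lower number from compound 1 to compound 3 (4.52 log units; beyond the scatter), a far larger step than the one at the ring, which places compound 3 as the strongest inhibitor of the three. The data at hand offer no explanation for the size or direction of either step.

The compounds shown leave open whether hydrogen is the best choice on this aromatic carbon, or whether a methoxy group, a fluorine atom or a chlorine atom there would give a lower or a higher number. They also leave open how the number changes across the range between the two groups already compared on the amine nitrogen, for example with an ethyl or propyl chain.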